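Shortening the Chain on Two Related Cores

This account rests on a few compounds, and the source may have more. Where it says the series, first, only, none or still open, it means among the compounds named here.

Compound 1 `CCCCCCCc1cc2cn(COCCO)c(O)nc-2n1`: in a functional assay on HEL cells (Homo sapiens), read by microscopy (a higher number here means that more compound is tolerated, a lower number that less compound is tolerated), compound 1 gives >= 400000 nM.
Compound 3 `CCCCCCCCCCCc1cc2cn(COCCO)c(O)nc-2n1`: in this assay compound 3 gives 80000 nM.
Compound 2 `CCCCCCCCCCCc1cc2cn(COCCO)c(=O)nc2o1`: in this assay compound 2 gives 80000 nM.

The value of compound 1 is a limit of the assay and not a number, as recorded in the limit of >= 400000 nM in this assay, at which 1 of the 3 values shown sits. Between compound 3 and compound 1 the change is hydrogen in place of butyl on a saturated chain carbon, seven bonds along the chain from an aromatic carbon, and it gives an at least 5.0-fold higher number from compound 3 to compound 1 (0.69 log units; beyond the scatter). Compound 2 and compound 3 carry the same long chain on different cores; how the two cores differ is not broken down here, and the two values are level at the digits given, within the scatter.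

Compound 4 `CCCCCCCc1cc2cn(COCCO)c(=O)nc2o1` is not yet measured. From compound 2 it differs by hydrogen in place of butyl on a saturated chain carbon, seven bonds along the chain from an aromatic carbon, the same change that was made from compound 3 to compound 1. The step is expected to read a 5.0-fold higher number from compound 2 to compound 4 (0.70 log units; beyond the scatter), resting on an at least 5.0-fold higher number from compound 3 to compound 1 (0.69 log units; beyond the scatter) for compound 1. Compound 4 is therefore estimated at 400000 nM, with a range from 200000 nM to 800000 nM, and it may well return only a limit.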

Compound 4, minimum cytotoxic concentration: 400000 nM
Compound 4: the middle estimate sits on the measured number at the digits printed; the measured number falls inside the stated range.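

In this assay, hydrogen in place of butyl gives a 5.0-fold higher number from compound 2 to compound 4 (0.70 log units; beyond the scatter), so the change moves the number in the same direction on both cores: the same change on two cores in this assay, an at least 5.0-fold higher number (0.69 log units; beyond the scatter) from compound 3 to compound 1 and a 5.0-fold higher number (0.70 log units; beyond the scatter) from compound 2 to compound 4; the limit leaves it open whether they differ

Compound 1 stands at a limit of the assay and not at a number: the limit of >= 400000 nM in this assay, at which 1 of the 4 values shown sits.

The two cores therefore agree in direction, but it is not shown that the size of the step carries over from one core to the other, and the pair says nothing about any further core.

The compounds shown leave open how the number behaves with chains of intermediate length, or with a chain shorter than those of compound 1 and compound 4. They also leave open whether either core would follow the same course with a phenyl ring in place of the chain, or with a chain that carries an amine.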